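The compounds below may be only part of what the source reports. "The series", "measured", "known", "first", "only" and "open" are said of these compounds alone.

Two compounds in this set share one core and differ only in the aromatic group attached to an aromatic nitrogen. Compound 1 `N#CC1=C(N)Oc2c(N)cc3nc4ccccc4nc3c2C12C(=O)N(Cc1cnnn1-c1cccc(C(F)(F)F)c1)c1ccccc12` gives 18900 nM in a functional assay on HCT-116 cells (Homo sapiens) for antiproliferative activity, read by MTT assay, with a stated time of 48 h; on this read-out higher numbers stand for weaker inhibition and lower numbers for stronger inhibition. Compound 2 `Cc1ccc(-n2nncc2CN2C(=O)C3(C(C#N)=C(N)Oc4c(N)cc5nc6ccccc6nc5c43)c3ccccc32)cc1C` reaches only the limit of > 50000 nM in this assay, so for compound 2 a range rather than a number is known. The step of an at least 2.6-fold higher number from compound 1 to compound 2 (0.42 log units; beyond the scatter) shows a weakening, though the limit of > 50000 nM in this assay, at which 1 of the 2 values shown sits, hides how far it runs. Compound 3 `N#CC1=C(N)Oc2c(N)cc3nc4ccccc4nc3c2C12C(=O)N(Cc1cnnn1-c1ccc([N+](=O)[O-])cc1[N+](=O)[O-])c1ccccc12` carries the change (2,4-dinitrophenyl in place of 3,4-dimethylphenyl on an aromatic nitrogen). For the measured compounds named here, only the step from compound 1 to compound 2 touches this position, and it gives no direct measure of the group that now enters, so the expectation rests on compound 2 sitting at the limit. Compound 3 is therefore expected to give about 35000 nM, within a range from 8000 nM to 50000 nM, which amounts to an expected step of an at least 1.4-fold lower number from compound 2 to compound 3 (0.15 log units; that floor lies within the scatter).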

Compound 3, half-maximal inhibitory concentration: 23900 nM
The estimate for compound 3 lay 1.5-fold (0.17 log units) above the measured number; the measured number falls inside the stated range.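

Moving to the 2,4-dinitrophenyl group gives an at least 2.0-fold lower number from compound 2 to compound 3 (0.32 log units; beyond the scatter) in this assay, so the weak result with 3,4-dimethylphenyl does not hold for every aromatic group at this position. Against the 3-(trifluoromethyl)phenyl group, the same group gives a 1.3-fold higher number from compound 1 to compound 3 (0.10 log units; within the scatter), so compound 1 and compound 3 cannot be told apart here, even though their aromatic groups carry different substituents. Compound 2 remains a limit rather than a number, so its step shows only a minimum size: the limit of > 50000 nM in this assay, at which 1 of the 3 values shown sits.

The compounds shown leave open how an unsubstituted phenyl ring, or a phenyl ring carrying a single nitro group or an amine, would behave. They also leave open whether an aromatic group is needed here at all, which a simple alkyl chain in its place could test.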